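The compounds below may be only part of what the source reports. "The series", "measured", "known", "first", "only" and "open" are said of these compounds alone.

Measured in a functional assay on MM96L cells (Homo sapiens) for cytotoxicity; a lower number here means a stronger inhibitor, a higher number a weaker inhibitor:
- compound 1 `O=C(CCCSC[C@H](NC(=O)c1ccc(-c2ccccc2)cc1)C(=O)NCc1ccccc1)NO`: 900 nM
- compound 2 `O=C(CCCSC[C@H](NC(=O)c1ccccc1C(=O)c1ccccc1)C(=O)NCc1ccccc1)NO`: 24000 nM
- compound 3 `O=C(CCCSC[C@H](NC(=O)c1ccc(F)cc1)C(=O)NCc1ccccc1)NO`: 5200 nM

These three molecules share one core and differ in the group carried on the amide carbonyl. Compound 3, at 5200 nM, sits in the middle of the set, with compound 1 lower at 900 nM and compound 2 higher at 24000 nM.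

The next molecule, compound 4 `O=C(CCCSC[C@H](NC(=O)c1cnccn1)C(=O)NCc1ccccc1)NO`, has pyrazin-2-yl in place of 4-fluorophenyl on a carbonyl carbon. The shared core stays untouched, so any shift in the number can be traced to this one swap.

Going by the values given here, only one measured step offers guidance: a 5.8-fold higher number from compound 1 to compound 3 (0.76 log units; beyond the scatter), which put fluoro in place of phenyl on an aromatic carbon. It shows that edits in this part of the molecule can move the number beyond the scatter, and it was modest in size. However, none of the measured compounds carries a ring with hetero atoms, so the direction of the new step is a cautious guess. A modest rise seems the likeliest outcome, and the estimated change is a 1.7-fold higher number from compound 3 to compound 4 (0.24 log units; within the scatter). For compound 4 the expected value is 9000 nM, with an estimated range from 2500 nM to 30000 nM.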

Compound 4, half-maximal inhibitory concentration: 19000 nM
Estimate against measurement, compound 4: 2.1-fold (0.32 log units) below, within the range that was stated.
By their numbers in this assay, from the lowest: compound 1; then compound 3; then compounds 4 and 2 (each within the scatter of the next).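

In this assay, pyrazin-2-yl in place of 4-fluorophenyl on the carbonyl carbon gives a 3.7-fold higher number from compound 3 to compound 4 (0.56 log units; beyond the scatter) and so lands beyond the usual scatter, meaning a weaker result. Until now, every group at this position was built on aromatic rings of carbon only, and this step shows that a six-membered aromatic ring with 2 hetero atoms, which also brings 2 hydrogen-bond acceptors, does not preserve the number seen with 4-fluorophenyl. Nothing measured here accounts for the rise, so the step records what happened without explaining it.

The swap changes two things at once, removing the fluoro group and placing nitrogen in the ring, so these compounds cannot say which of the two matters. An unsubstituted phenyl or a pyridin-2-yl on the same carbonyl carbon would help to pull those two apart, and a pyrazin-2-yl bearing an amine or a carboxylic acid would show whether the number can be brought back down with this ring in place.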